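Cytotoxicity notes on compound 4 versus three measured analogues

A few compounds are considered here, and "the series" means these few. Any claim that something is new, unique, unknown or untested is made for them only; others in the source may bear on it.

Going by the values given here, compound 3 `Cc1ccc2nc(N3CCCc4ccc(F)cc4C3)cc(NCCN(C)C)c2c1` is the only member of the set with a numeric reading in an ADME assay on HEp-2 cells (Homo sapiens) for cytotoxicity, read by CCK-8 assay, with a stated time of 5 days; a lower number here means that less compound is tolerated, a higher number that more compound is tolerated: compound 3 gives 89000 nM. Compound 1 `Cc1ccc2nc(N3CCCc4ccc(F)cc4C3)cc(NCC3(N)COC3)c2c1` gives > 100000 nM, which is a limit of the assay, namely (the limit of > 100000 nM in this assay, at which 1 of the 3 values shown sits). Compound 2 `Cc1ccc2nc(N3CCCc4ccc(F)cc4C3)cc(NCCN)c2c1` gives > 3200 nM, likewise a limit, namely (the limit of > 3200 nM in this assay, at which 1 of the 3 values shown sits). Hence an at least 1.1-fold lower number from compound 1 to compound 3 (0.05 log units; that floor lies within the scatter) lies within the scatter, while a step that the two limits leave unreadable from compound 1 to compound 2 and a step that the limit leaves unreadable from compound 2 to compound 3 cannot be read. Compound 4 `Cc1ccc2nc(N3CCCc4ccc(F)cc4C3)cc(NCC(C)N)c2c1` differs from compound 3 by 1-aminoethyl in place of (dimethylamino)methyl on a saturated chain carbon bound to a nitrogen on an aromatic ring. Among the compounds with values here, the step from compound 2 to compound 3, exchanging amino for dimethylamino on the chain, bears most closely on this change, yet its size is unreadable, so no measured step gives a direction beyond the scatter. Compound 4 is expected to give 80000 nM in this assay, within 20000 nM to 200000 nM, an expected step of a 1.1-fold lower number from compound 3 to compound 4 (0.05 log units; within the scatter).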

Compound 4, half-maximal cytotoxic concentration: 86000 nM
The estimate for compound 4 lay 1.1-fold (0.03 log units) below the measured number; the range from low to high includes it.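

In this assay the exchange of (dimethylamino)methyl for 1-aminoethyl gives a 1.0-fold lower number from compound 3 to compound 4 (0.01 log units; within the scatter) on this saturated chain carbon, so this change, which adds a hydrogen-bond donor, leaves the reading within the scatter. Likewise, an at least 1.1-fold lower number from compound 1 to compound 4 (0.06 log units; that floor lies within the scatter) does not separate 1-aminoethyl from 3-aminooxetan-3-yl at this place.

Open, as far as these compounds go, is whether a longer chain or a carboxylic acid in place of the amine would take the reading beyond the scatter. Steps involving compound 2 cannot be read, because its value is a limit: the limit of > 3200 nM in this assay, at which 1 of the 4 values shown sits.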